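Fluoro to chloro step on the phenoxy ring, lipophilicity notes

A few compounds are considered here, and "the series" means these few. Any claim that something is new, unique, unknown or untested is made for them only; others in the source may bear on it.

Measured compounds:
compound 1 `CC(Oc1ccc(Oc2ccc(F)cc2)cc1)C(=O)Cn1nnc(-c2ccc(Cl)cc2)n1` gives 6.2 in a physicochemical assay for lipophilicity, read by HPLC, tested at 5 mM; on this read-out higher numbers stand for higher lipophilicity and lower numbers for lower lipophilicity
compound 2 `CC(Oc1ccc(Oc2ccc(Cl)cc2)cc1)C(=O)Cn1nnc(-c2ccc(Cl)cc2)n1` gives 6.8
compound 3 `COC(=O)c1ccc(-c2nnn(CC(=O)C(C)Oc3ccc(Oc4ccc(F)cc4)cc3)n2)cc1` gives 5.4

Compound 1 and compound 2 differ in one place: chloro in place of fluoro on an aromatic carbon. This gives a number 0.60 log units higher from compound 1 to compound 2 (beyond the scatter). Compound 3 carries a different core; the difference from compound 1 is methoxycarbonyl in place of chloro on an aromatic carbon, with a number 0.80 log units lower from compound 1 to compound 3 (beyond the scatter). Compound 3 stands lowest of the three measured compounds.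

Compound 4 `COC(=O)c1ccc(-c2nnn(CC(=O)C(C)Oc3ccc(Oc4ccc(Cl)cc4)cc3)n2)cc1` is not yet measured. It differs from compound 3 by chloro in place of fluoro on an aromatic carbon, the same change as from compound 1 to compound 2, at a place described in identical words. For compound 4 a step of a number 0.60 log units higher from compound 3 to compound 4 (beyond the scatter) is expected, because a number 0.60 log units higher from compound 1 to compound 2 (beyond the scatter) on the other core. The estimate rests on a single earlier instance of the change and on the two cores behaving alike. Compound 4 is therefore estimated at 6, between 5.6 and 6.4.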

Compound 4, partition coefficient: 6.1
Compound 4: the middle estimate sits 0.10 log units below what was measured, and the stated range covers the measured number.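

In this assay the change of fluoro to chloro gives a number 0.70 log units higher from compound 3 to compound 4 (beyond the scatter) on the core of compound 3 and a number 0.60 log units higher from compound 1 to compound 2 (beyond the scatter) on the core of compound 1, so across these two cores it runs the same way at a similar size. The change of chloro to methoxycarbonyl reads alike, with a number 0.70 log units lower from compound 2 to compound 4 (beyond the scatter) against a number 0.80 log units lower from compound 1 to compound 3 (beyond the scatter). This is a single pair on each core and does not show that the change carries to any further core, and nothing on hand accounts for the size of either step.

Open, from the compounds shown here alone, is whether the fluoro to chloro step keeps its size with a carboxylic acid or an amine in place of methoxycarbonyl. Also open, going by these compounds, is how bromo or trifluoromethyl in place of chloro would read in this assay.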